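The compounds below may be only part of what the source reports. "The series", "measured", "known", "first", "only" and "open" are said of these compounds alone.

Three esters sharing one core have been measured so far in a functional assay, with a stated time of 60 min (on this read-out lower numbers stand for stronger inhibition and higher numbers for weaker inhibition), to date. Compound 1 (`O=C(/C=C/c1ccc(O)c(O)c1)OCCOc1no[n+]([O-])c1S(=O)(=O)c1ccccc1`) gives 219000 nM there, compound 2 (`O=C(OCCOc1no[n+]([O-])c1S(=O)(=O)c1ccccc1)c1ccc(O)c(O)c1`) gives 275000 nM there, and compound 3 (`COc1cc(/C=C/C(=O)OCCOc2no[n+]([O-])c2S(=O)(=O)c2ccccc2)ccc1O`) gives 669000 nM as the highest number of the three, which makes it the weakest inhibitor of the set. Compound 4 (`O=C(/C=C/c1ccccc1)OCCOc1no[n+]([O-])c1S(=O)(=O)c1ccccc1`) is still unmeasured and differs from compound 3 by one change (phenyl in place of 4-hydroxy-3-methoxyphenyl on a double-bonded chain carbon bound to a double-bonded chain carbon) that puts phenyl in place of 4-hydroxy-3-methoxyphenyl. Among the compounds with values here, two measured steps bear on this. One lay within the scatter (a 1.3-fold higher number from compound 1 to compound 2 (0.10 log units; within the scatter)) and says little here. The other altered the same ring and was modest (a 3.1-fold higher number from compound 1 to compound 3 (0.48 log units; beyond the scatter)) but beyond the scatter. Within the data shown here, no measured compound has a bare phenyl, so this is an extrapolation. A further modest rise in the number, meaning weaker inhibition, is expected in this assay on that second step alone. The expected change is a 2.2-fold higher number from compound 3 to compound 4 (0.35 log units; beyond the scatter) on this reasoning. The estimated value for compound 4 is 1500000 nM with an expected range from 600000 nM to 3500000 nM on present evidence.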

Compound 4, half-maximal inhibitory concentration: > 10000000 nM
Compound 4: a limit, no number; the forecaster's own chance of this, stated with the estimate: 30%; middle value at least 6.6-fold (0.82 log units) away from the limit.
By their numbers in this assay, from the lowest: compounds 1 and 2 (each within the scatter of the next); then compound 3. At a limit, above all of these: compound 4.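

In this assay compound 4 stands at a limit and not at a number: the limit of > 10000000 nM in this assay, at which 1 of the 4 values shown sits. At this place, on a double-bonded chain carbon bound to a double-bonded chain carbon, phenyl in place of 4-hydroxy-3-methoxyphenyl gives an at least 14-fold higher number from compound 3 to compound 4 (1.17 log units; beyond the scatter), and phenyl in place of 3,4-dihydroxyphenyl gives an at least 45-fold higher number from compound 1 to compound 4 (1.65 log units; beyond the scatter). Within the data shown here, both steps are large, as is 2-phenylethenyl in place of 3,4-dihydroxyphenyl on a carbonyl carbon, an at least 36-fold higher number from compound 2 to compound 4 (1.56 log units; beyond the scatter), so the ring's substituents matter far more than the earlier compounds, all of which carried them, could show.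

The compounds shown leave open whether a single hydroxy group on the phenyl ring would be enough to bring the number back down. They also leave open whether an amine or a carboxylic acid on that ring could take the place of the hydroxy groups.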